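A few compounds are considered here, and "the series" means these few. Any claim that something is new, unique, unknown or untested is made for them only; others in the source may bear on it.

Of the compounds shown here, three built on one shared core have been tested in a functional assay on Jurkat cells (Homo sapiens) for inhibition; on this read-out higher numbers stand for weaker inhibition and lower numbers for stronger inhibition. Compound 1 `CC(C)[C@H](NC(=O)COc1cccc2ccccc12)C(=O)N[C@@H](CC(=O)O)C(=O)CSc1nc(-c2ccccc2)c(-c2ccccc2)[nH]1` gives only a limit of the assay, > 200000 nM. Compound 2 `CC(C)[C@H](NC(=O)COc1cccc2ccccc12)C(=O)N[C@@H](CC(=O)O)C(=O)CSc1nc(-c2ccccc2)no1` gives 102000 nM. Compound 3 `CC(C)[C@H](NC(=O)COc1cccc2ccccc12)C(=O)N[C@@H](CC(=O)O)C(=O)CSc1nnc(-c2ccccc2)o1` gives 150000 nM, which is the higher of the two numbers shown; the step of a 1.5-fold higher number from compound 2 to compound 3 (0.17 log units; within the scatter) lies within the scatter, so compound 2 and compound 3 cannot be told apart on this read-out.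

Compound 4 `Cc1cc(OCC(=O)[C@H](CC(=O)O)NC(=O)[C@@H](NC(=O)COc2cccc3ccccc23)C(C)C)nc(C)n1` differs from compound 3 at the saturated chain carbon bound to a carbonyl carbon: (2,6-dimethylpyrimidin-4-yl)oxy in place of (5-phenyl-1,3,4-oxadiazol-2-yl)sulfanyl on a saturated chain carbon bound to a carbonyl carbon. For the measured compounds named here, no measured step covers this exchange of an oxygen-linked pyrimidine for a sulfur-linked oxadiazole. Going by the values given here, the one step available, a 1.5-fold higher number from compound 2 to compound 3 (0.17 log units; within the scatter), swapped only the heteroaryl ring on the sulfur and produced no shift beyond the scatter. Compound 1, which carries yet another group at this position, sits at the limit (the limit of > 200000 nM in this assay, at which 1 of the 3 values shown sits).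

The data therefore give no footing for a large step in either direction, and any expectation must stay wide. Compound 4 is expected at 40000 nM, with a range from 5000 nM to 150000 nM. The estimated step of a 3.8-fold lower number from compound 3 to compound 4 (0.57 log units; beyond the scatter) is expected to be modest, tilted toward a somewhat lower number, but with little confidence.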

Compound 4, half-maximal inhibitory concentration: > 200000 nM
Compound 4: no number, only a limit; the forecaster's own chance of this, stated with the estimate: 15%; middle value at least 5.0-fold (0.69 log units) from the limit.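

In this assay compound 4 gives only a limit of the assay, which makes the oxygen-linked pyrimidine the second group at this position to stop at that limit: the limit of > 200000 nM in this assay, at which 2 of the 4 values shown sit.

Set against the sulfur-linked oxadiazoles, the change reads as an at least 1.3-fold higher number from compound 3 to compound 4 (0.12 log units; that floor lies within the scatter) and as an at least 1.9-fold higher number from compound 2 to compound 4 (0.29 log units; that floor lies within the scatter); both figures are only floors, so the true size of each step is unknown, and neither floor by itself shows a real loss. What the result does add is that moving from a sulfur-linked five-membered ring carrying a phenyl to a smaller oxygen-linked dimethylpyrimidine, on a saturated chain carbon bound to a carbonyl carbon, brought no measurable gain in inhibition.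

As far as these compounds go, compound 4 changes the linking atom and the ring at once, so it stays open which of the two matters, and a (2,6-dimethylpyrimidin-4-yl)sulfanyl group at this place would separate them. From the compounds shown here alone, compound 1 and compound 4 both end at a limit and so cannot be ranked against each other, and it also remains unknown whether a simpler group here, such as a phenoxy or a fluorine, would give stronger inhibition.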